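Aryl Methyl on the Spirooxindole Core of Compound 3

A few compounds are considered here, and "the series" means these few. Any claim that something is new, unique, unknown or untested is made for them only; others in the source may bear on it.

Compound 1 `CN1C(=O)C2(C(C#N)=C(N)Oc3cc4oc(-c5ccccc5)cc(=O)c4c(O)c32)c2ccccc21` is the parent of this small set. In a functional assay on A549 cells (Homo sapiens) for antiproliferative activity, read by MTT assay, with a stated time of 48 h (a lower number here means a stronger inhibitor, a higher number a weaker inhibitor), compound 1 gives > 50000 nM, which is a limit of the measurement, the limit (the limit of > 50000 nM in this assay, at which 1 of the 3 values shown sits), and not a number. Compound 2 `Cc1ccc2c(c1)C1(C(=O)N2C)C(C#N)=C(N)Oc2cc3oc(-c4ccccc4)cc(=O)c3c(O)c21` differs from compound 1 by methyl in place of hydrogen on an aromatic carbon, and in this assay compound 2 gives 7060 nM. The step is an at least 7.0-fold lower number from compound 1 to compound 2 (0.85 log units; beyond the scatter), its true size unknown because the limit of > 50000 nM in this assay, at which 1 of the 3 values shown sits, is where compound 1 sits.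

Compound 3 `N#CC1=C(N)Oc2cc3oc(-c4ccccc4)cc(=O)c3c(O)c2C12C(=O)Nc1ccccc12` differs from compound 1 in a different place, (hydrogen in place of methyl on an amide-type nitrogen in a ring). In this assay compound 3 gives 37600 nM. The step is an at least 1.3-fold lower number from compound 1 to compound 3 (0.12 log units; that floor lies within the scatter), and it too is a floor rather than a size. Of the two measured numbers, compound 3 has the higher one, compound 2 the lower.

Compound 4 `Cc1ccc2c(c1)C1(C(=O)N2)C(C#N)=C(N)Oc2cc3oc(-c4ccccc4)cc(=O)c3c(O)c21` has not been measured. Going by the values given here, it differs from compound 3 by methyl in place of hydrogen on an aromatic carbon, the same change, at the same place, as the one made from compound 1 to compound 2. If that change acts on the core of compound 3 as it did on the core of compound 1, the step of a 7.5-fold lower number from compound 3 to compound 4 (0.88 log units; beyond the scatter) is expected, resting on the step of an at least 7.0-fold lower number from compound 1 to compound 2 (0.85 log units; beyond the scatter) made from compound 1 to compound 2. On that basis compound 4 is estimated to give 5000 nM in this assay, most likely between 1500 nM and 15000 nM.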

Compound 4, half-maximal inhibitory concentration: > 50000 nM
Compound 4 gave a limit, no number; the forecaster's own chance of this, stated with the estimate: 5%; middle value at least 10-fold (1.00 log units) away from the limit.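

In this assay compound 4 gives > 50000 nM, which is a limit of the assay and not a number, and it shares that limit with the parent: the limit of > 50000 nM in this assay, at which 2 of the 4 values shown sit.

The methyl on the aromatic carbon does not carry over from the core of compound 1 to the core of compound 3, for here the step is an at least 1.3-fold higher number from compound 3 to compound 4 (0.12 log units; that floor lies within the scatter), a floor that does not show the methyl raising the number on this core, only that the drop seen on the core of compound 1 did not recur: the same change on two cores in this assay, an at least 7.0-fold lower number (0.85 log units; beyond the scatter) from compound 1 to compound 2 and an at least 1.3-fold higher number (0.12 log units; that floor lies within the scatter) from compound 3 to compound 4, at least 9.4-fold (0.97 log units) apart, beyond the scatter of two such steps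

The other change in the square, hydrogen in place of methyl on the amide-type nitrogen, also depends on its core, with a step of an at least 7.0-fold higher number from compound 2 to compound 4 (0.85 log units; beyond the scatter), although the true sizes of these steps stay unknown and four compounds show no reason for the difference: the same change on two cores in this assay, an at least 1.3-fold lower number (0.12 log units; that floor lies within the scatter) from compound 1 to compound 3 and an at least 7.0-fold higher number (0.85 log units; beyond the scatter) from compound 2 to compound 4, at least 9.4-fold (0.97 log units) apart, beyond the scatter of two such steps

The compounds shown leave open whether this dependence on the core holds for groups other than methyl on the same aromatic carbon, such as chloro or methoxy. They also leave open how an ethyl group or a longer chain on the amide-type nitrogen would behave with and without that aromatic methyl.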